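A few compounds are considered here, and "the series" means these few. Any claim that something is new, unique, unknown or untested is made for them only; others in the source may bear on it.

Measured so far in a functional assay for antagonist activity at Alpha-1A adrenergic receptor (Oryctolagus cuniculus); on this read-out lower numbers stand for tighter binding and higher numbers for weaker binding:

compound 1 `COc1ccccc1N1CCN(CCCNc2ncccc2C(=O)N(C)C)CC1` gives 1.59 nM
compound 2 `CN(C)C(=O)c1cccnc1NCCCN1CCN(c2ccccc2)CC1` gives 6.31 nM
compound 3 `CSc1ccccc1N1CCN(CCCNc2ncccc2C(=O)N(C)C)CC1` gives 0.631 nM

Compound 3 stands lowest of the three numbers in this assay; its nearest neighbour is compound 1, its furthest compound 2. The steps that lead to it are a 2.5-fold lower number from compound 1 to compound 3 (0.40 log units; beyond the scatter) and a 10-fold lower number from compound 2 to compound 3 (1.00 log units; beyond the scatter), both beyond the scatter; the remaining step, a 4.0-fold higher number from compound 1 to compound 2 (0.60 log units; beyond the scatter), runs the other way. Every gain so far comes from the group on this aromatic carbon, and the methylsulfanyl group has given the best number.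

Compound 4 `CN(C)C(=O)c1cccnc1NCCCN1CCN(c2ccccc2C(F)(F)F)CC1` differs from compound 3 by trifluoromethyl in place of methylsulfanyl on an aromatic carbon. Among the compounds with values here, no measured step covers a trifluoromethyl group at this place, so the expectation rests only on the spread the three groups show: hydrogen sits furthest off, methoxy in between, methylsulfanyl lowest. A trifluoromethyl group is a fresh case, and a step in this assay within the span set by compound 2 and compound 3 is expected, most likely upward from compound 3. The step expected for compound 4 is a 4.0-fold higher number from compound 3 to compound 4 (0.60 log units; beyond the scatter). For compound 4 an estimate of 2.5 nM in this assay is made, with a range from 0.8 nM to 8 nM.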

Compound 4, dissociation constant: 12.6 nM
Estimate against measurement, compound 4: 5.0-fold (0.70 log units) below, and the stated range ends below it.
By their numbers in this assay, from the lowest: compound 3; then compound 1; then compounds 2 and 4 (each within the scatter of the next).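

Filling this aromatic carbon, ortho to a large group, does not by itself lower the number in this assay: trifluoromethyl set against hydrogen gives a 2.0-fold higher number from compound 2 to compound 4 (0.30 log units; within the scatter), so these two groups are not separated here. Trifluoromethyl also loses what the other two groups gained, with a 7.9-fold higher number from compound 1 to compound 4 (0.90 log units; beyond the scatter) and a 20-fold higher number from compound 3 to compound 4 (1.30 log units; beyond the scatter), the largest step in the series so far, so the lower numbers at this place belong to methoxy and methylsulfanyl and not to substitution as such. No measurement is available that accounts for this difference between the groups.

Going by these compounds, it remains open whether an ethylsulfanyl group, an ethoxy group, a chlorine atom or an amine at this place would match methylsulfanyl. The order of the groups is also untested on any other aromatic carbon of this ring.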